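Swapping an Ether Linker for a Thioether Linker

A few compounds are considered here, and "the series" means these few. Any claim that something is new, unique, unknown or untested is made for them only; others in the source may bear on it.

Of the compounds shown here, two built on a shared core have been tested in a functional assay on NCI-H460 cells (Homo sapiens) for inhibition, read by sulforhodamine B assay, with a stated time of 48 h; on this read-out lower numbers stand for stronger inhibition of growth and higher numbers for weaker inhibition of growth. Compound 1, `COc1ccc(Sc2nc3cc(N)cc(N)c3nc2-c2ccccc2)cc1`, carries a (4-methoxyphenyl)sulfanyl group. In this assay compound 1 gives only a limit of < 100000 nM. Compound 2, `Nc1cc(N)c2nc(-c3ccccc3)c(Oc3ccc(F)cc3)nc2c1`, carries a 4-fluorophenoxy group in that place. In this assay compound 2 likewise gives only a limit of < 100000 nM. The step that the two limits leave unreadable from compound 1 to compound 2 cannot be read, because of the limit of < 100000 nM in this assay, at which 2 of the 2 values shown sit. Compound 3, `Nc1cc(N)c2nc(-c3ccccc3)c(Sc3ccc(F)cc3)nc2c1`, differs from compound 2 by (4-fluorophenyl)sulfanyl in place of 4-fluorophenoxy on an aromatic carbon. Within the data shown here, no measured step bears directly on this exchange of oxygen for sulfur, and compound 2 itself stands at a limit rather than at a number. The step that the limit leaves unreadable from compound 2 to compound 3 is therefore only an estimate, and no change beyond the usual scatter is expected. Compound 3 is expected to reach about 20000 nM, within a range from 3000 nM to 100000 nM in this assay.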

Compound 3, concentration for total growth inhibition: 66100 nM
Compound 3: the middle estimate sits 3.3-fold (0.52 log units) below what was measured, and the stated range covers the measured number.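

The steps linking compound 1, compound 2 and compound 3 cannot be read, because compound 1 and compound 2 give only limits: the limit of < 100000 nM in this assay, at which 2 of the 3 values shown sit. The compounds shown leave open whether sulfur in place of oxygen, or fluoro in place of methoxy, changes the result in this assay at all.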